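The compounds below may be only part of what the source reports. "The series", "measured", "known", "first", "only" and "open" are said of these compounds alone.

In a functional assay on KG-1 cells (Homo sapiens) for cytotoxicity, read by luminescence and CellTiter-Glo, with a stated time of 3 days (a lower number here means a stronger inhibitor, a higher number a weaker inhibitor), compound 1 (`N#Cc1ccc(NC(=O)c2cc(Br)c3cccnc3c2O)cc1`) stands as "not determined" (no result reported), so it offers no number for comparison. Among the compounds with values here, compound 2 (`Cc1cc(C#N)ccc1NC(=O)c1ccc2cccnc2c1O`) gives 3240 nM, the only number, so it cannot yet be ranked against anything. Compound 3 (`N#Cc1ccc(NC(=O)c2ccc3cccnc3c2O)cc1`) remains to be measured. It differs from compound 2 by one change, hydrogen in place of methyl on an aromatic carbon, ortho to a large group and meta to a cyano group. Within the data shown here, no measured pair shows the effect of this change. With only compound 2 at 3240 nM to go on, no step beyond the usual scatter is expected in this assay, and no direction is favoured. The expected step is a 1.1-fold lower number from compound 2 to compound 3 (0.03 log units; within the scatter). For compound 3 the estimated value is 3000 nM, with an expected range from 1000 nM to 9000 nM.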

Compound 3, half-maximal inhibitory concentration: 2320 nM
For compound 3 the middle estimate is 1.3-fold (0.11 log units) above the measured one; measured number inside the range.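

In this assay, hydrogen in place of methyl on the aromatic carbon, ortho to a large group and meta to a cyano group, gives a 1.4-fold lower number from compound 2 to compound 3 (0.15 log units; within the scatter) and so leaves the two compounds indistinguishable. At this position, methyl is therefore not required for the activity seen in this assay, and its removal causes no loss that can be read from this pair. No measured data bear on why the step is this small.

On these data alone, with only methyl and hydrogen compared at this carbon, it remains open whether a fluorine, a methoxy group or an amine there would move the number beyond the scatter. Also open, as far as these compounds go, is whether this tolerance holds when other parts of the molecule change, such as the amide or the shared core.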